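From fluorophenyl to methylphenyl on a shared core

The source may report more compounds than this note shows. Statements on the series, on what has been measured and on what is new or still open speak of the compounds shown alone.

Three measured compounds share one core and differ only in where the fluorine sits on the phenyl group attached to the five-membered aromatic ring with 4 nitrogen. In an assay on HEK293 cells for activation of Kir3.1/Kir3.2 (Homo sapiens), read by thallium flux (a lower number here means a smaller maximal response, a higher number a larger maximal response), compound 1 `Cc1cc(NC(=O)Cn2nnc(-c3ccc(F)cc3)n2)n(C2CCCCC2)n1` gives 92%, compound 2 `Cc1cc(NC(=O)Cn2nnc(-c3cccc(F)c3)n2)n(C2CCCCC2)n1` gives 96%, and compound 3 `Cc1cc(NC(=O)Cn2nnc(-c3ccccc3F)n2)n(C2CCCCC2)n1` gives 88%. Compound 3 stands where a number 4 percentage points lower from compound 1 to compound 3 (within the scatter) and a number 8 percentage points lower from compound 2 to compound 3 (within the scatter) place it, and with a number 4 percentage points higher from compound 1 to compound 2 (within the scatter) none of the three steps leaves the scatter.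

Compound 4 `Cc1ccc(-c2nnn(CC(=O)Nc3cc(C)nn3C3CCCCC3)n2)cc1` has not yet been measured. Its change from compound 3 is 4-methylphenyl in place of 2-fluorophenyl on an aromatic carbon. Among the measured compounds shown here, the measured steps that bear on it are the three fluorine moves, each within the scatter; none of them tests a methyl group, so the step itself has no direct precedent among the three. The fluorine moves all stay within the scatter, and the entering group keeps the same ring size and heavy-atom count as the leaving one, so the account expects no step beyond the scatter in this assay, the estimated step being a number 2 percentage points higher from compound 3 to compound 4 (within the scatter). Compound 4 is therefore estimated at 90% in this assay, with a range from 76% to 102%.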

Compound 4, largest response reached (Emax), in percent of the reference or control that the assay uses: 86%
Estimate against measurement, compound 4: 4 percentage points above, and the stated range covers the measured number.
By their numbers in this assay, from the lowest: compounds 4, 3, 1 and 2 (each within the scatter of the next).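

In this assay, among the compounds shown here, the move from fluoro to methyl on the phenyl group, the first change here that replaces the substituent rather than moving it, gives a number 6 percentage points lower from compound 1 to compound 4 (within the scatter) and so does not leave the scatter. The two steps that also change the place of the substituent read the same way, with a number 2 percentage points lower from compound 3 to compound 4 (within the scatter) and a number 10 percentage points lower from compound 2 to compound 4 (within the scatter) both printed as within the scatter, so on the aromatic carbon between two ring nitrogen atoms 4-methylphenyl cannot be told apart from any of the three fluorophenyl groups in this assay. The range of substituents that leaves the read-out unchanged at this position therefore now includes a carbon substituent as well as fluorine, though nothing shown here accounts for that sameness.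

On these data alone, all four compounds carry a phenyl group with one small substituent, so it remains open whether a carboxylic acid, an amine or a methoxy group on that phenyl would give a step beyond the scatter. As far as these compounds go, it also remains open whether methyl would read the same at the other two ring places that fluorine occupies.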